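Nitrophenyl shift in a series at the assay limit

The compounds below may be only part of what the source reports. "The series", "measured", "known", "first", "only" and "open" are said of these compounds alone.

Compound 1 (`CC1=CC[C@@H]([C@@](C)(O)CCCC(C)(C)NC(=S)N/N=C\c2ccc(O)cc2)CC1`) carries 4-hydroxyphenyl and compound 2 (`CC1=CC[C@@H]([C@@](C)(O)CCCC(C)(C)NC(=S)N/N=C\c2cccc([N+](=O)[O-])c2)CC1`) carries 3-nitrophenyl on a carbon with a double bond to nitrogen. In a functional assay on NCI-H460 cells (Homo sapiens) for cytotoxicity, read by sulforhodamine B assay (a lower number here means that less compound is tolerated, a higher number that more compound is tolerated), compound 1 gives > 100000 nM as a limit of the assay. In this assay compound 2 gives > 100000 nM as a limit too, so it has no number of its own. Among the compounds with values here, the series so far stands at the limit of > 100000 nM in this assay, at which 2 of the 2 values shown sit, and no further.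

Compound 3 (`CC1=CC[C@@H]([C@@](C)(O)CCCC(C)(C)NC(=S)N/N=C\c2ccc([N+](=O)[O-])cc2)CC1`) differs from compound 2 by 4-nitrophenyl in place of 3-nitrophenyl on a carbon with a double bond to nitrogen. Within the data shown here, the only measured step, a step that the two limits leave unreadable from compound 1 to compound 2, bears on this change but gives no size to carry over. No step beyond the scatter is expected in this assay in either direction, and a reading at the same limit is the likeliest outcome. The expected step is a number no higher from compound 2 to compound 3 (the limit leaves the size open) as estimated. The estimate for compound 3 is 100000 nM with an expected range from 40000 nM to 200000 nM for a measured number.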

Compound 3, concentration lethal to 50% of the cells: > 100000 nM
Compound 3: no number, only a limit; the forecaster's own chance of this, stated with the estimate: 75%; the middle value sits exactly at the limit.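

No step can be read between compound 1, compound 2 and compound 3 in this assay, as each gives only a limit of the assay and no number: the limit of > 100000 nM in this assay, at which 3 of the 3 values shown sit.

The compounds shown leave open whether hydroxy or nitro, or either nitrophenyl, makes any difference in this assay.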